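Trifluoromethyl in place of fluoro on compound 3

The compounds below may be only part of what the source reports. "The series", "measured", "known", "first", "only" and "open" are said of these compounds alone.

Three amides on the shared core have been measured in a functional assay on PBMC cells (Homo sapiens) for inhibition, read by HTRF, with stated times of 15 min and 24 h; on this read-out lower numbers stand for stronger inhibition and higher numbers for weaker inhibition. Compound 1 `O=C(Nc1ccc2c(c1)B(O)OC2)c1ccccc1C(F)(F)F` gives 2100 nM. Compound 3 `O=C(Nc1ccc2c(c1)B(O)OC2)c1cc(F)ccc1C(F)(F)F` gives 11000 nM, the higher of the two actual numbers, and compound 1 is its nearest neighbour. Compound 2 `O=C(Nc1ccc2c(c1)B(O)OC2)c1cccc(C(F)(F)F)c1` gives > 10000 nM, which is a limit of the assay and not a number.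

Compound 4 `O=C(Nc1ccc2c(c1)B(O)OC2)c1cc(C(F)(F)F)ccc1C(F)(F)F` differs from compound 3 as follows: trifluoromethyl in place of fluoro on an aromatic carbon. This is trifluoromethyl in place of fluoro on an aromatic carbon, para to a trifluoromethyl group. Among the measured compounds shown here, one measured step bears on it: a 5.2-fold higher number from compound 1 to compound 3 (0.72 log units; beyond the scatter), with fluoro in place of hydrogen on an aromatic carbon, a modest move toward weaker inhibition. No exchange of fluoro for trifluoromethyl has been measured, so the size remains uncertain. Only a small move toward higher numbers is expected in this assay, one that may not clear the scatter. The expected step is a 1.3-fold higher number from compound 3 to compound 4 (0.10 log units; within the scatter). Compound 4 is estimated at 14000 nM, with an expected range from 5000 nM to 40000 nM.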

Compound 4, half-maximal inhibitory concentration: 2000 nM
Estimate against measurement, compound 4: 7.0-fold (0.85 log units) above; the whole stated range lies above it.
By their numbers in this assay, from the lowest: compounds 4 and 1 (each within the scatter of the next); then compound 3.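

In this assay, the shift seen with fluoro at this carbon, a 5.2-fold higher number from compound 1 to compound 3 (0.72 log units; beyond the scatter), does not extend to trifluoromethyl, which gives a 5.5-fold lower number from compound 3 to compound 4 (0.74 log units; beyond the scatter) and, against the hydrogen, a 1.1-fold lower number from compound 1 to compound 4 (0.02 log units; within the scatter). Compound 2, which carries trifluoromethyl at this carbon but lacks the other trifluoromethyl group, gives > 10000 nM, a limit and not a number. Adding that other group gives an at least 5.0-fold lower number from compound 2 to compound 4 (0.69 log units; beyond the scatter), so trifluoromethyl at this carbon is compatible with the lower numbers only in compound 4, and the size of this step stays open-ended: the limit of > 10000 nM in this assay, at which 1 of the 4 values shown sits.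

Only hydrogen, fluoro and trifluoromethyl are shown at this carbon, so the series does not yet tell whether fluoro or trifluoromethyl is the exception. A methyl, a methoxy group, a chlorine or a nitrile at the same carbon would help to settle this.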